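This account rests on a few compounds, and the source may have more. Where it says the series, first, only, none or still open, it means among the compounds named here.

Measured in a physicochemical assay for solubility, read by spectrophotometry, in phosphate buffer, with a stated time of 18 h, at pH 7.4; a lower number here means a less soluble compound, a higher number a more soluble compound:
- Compound 1 `CCc1ccc(-c2nc3c(c(C)nn3-c3ccccc3)c(-c3ccccc3F)c2C#N)cc1`: 1700 nM
- Compound 2 `CCc1ccc(-c2nc3c(c(C)nn3-c3ccccc3)c(-c3ccccc3C(=O)O)c2C#N)cc1`: 33000 nM

Compound 2 stands highest of the two measured compounds. Within the data shown here, the only measured step is a 19-fold higher number from compound 1 to compound 2 (1.29 log units; beyond the scatter), which is large and beyond the scatter, with carboxy in place of fluoro on an aromatic carbon.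

Compound 3 `CCc1ccc(-c2nc3c(c(C)nn3-c3ccccc3)c(-c3ccccc3OC(F)(F)F)c2C#N)cc1` has not yet been measured in this assay. Its difference from compound 2 is trifluoromethoxy in place of carboxy on an aromatic carbon, with trifluoromethoxy in place of carboxy on an aromatic carbon. Like the measured step, this change involves carboxy, but in the opposite direction. Among the measured compounds shown here, no measured step involves trifluoromethoxy, so the size is uncertain. A large drop is expected in this assay, returning to the neighbourhood of compound 1 at 1700 nM. The estimated step is a 33-fold lower number from compound 2 to compound 3 (1.52 log units; beyond the scatter). For compound 3 the expected value is 1000 nM, with an estimated range of 250 nM to 3500 nM.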

Compound 3, solubility: 9900 nM
Compound 3: middle estimate off by 9.9-fold (1.00 log units), on the low side; the measured number lies above the stated range.
By their numbers in this assay, from the lowest: compound 1; then compound 3; then compound 2.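

In this assay a higher number at this position is not confined to carboxy: trifluoromethoxy in place of fluoro also gives a rise beyond the scatter (a 5.8-fold higher number from compound 1 to compound 3 (0.77 log units; beyond the scatter)). Trifluoromethoxy, with 0 hydrogen-bond donors, gives up only part of the gain from carboxy (a 3.3-fold lower number from compound 2 to compound 3 (0.52 log units; beyond the scatter)), leaving the order of these three compounds as fluoro, trifluoromethoxy, carboxy. No measurement here bears on why the numbers fall in this order.

Going by these compounds, how methoxy, trifluoromethyl or an amine would read at this position remains open, and three groups are too few to tie the numbers to any feature of the group. On these data alone, whether the same steps hold with another group in place of the ethyl chain on the shared core is also open.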